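Compound 3: acetamido in place of ((tert-butyl)carbonyl)oxy

The source may hold more compounds than are shown below. What is called first, only, known or untested is meant among the compounds shown, and "the series" means these compounds.

In a functional assay on CCRF-CEM cells (Homo sapiens) for antiproliferative activity (on this read-out higher numbers stand for weaker inhibition of growth and lower numbers for stronger inhibition of growth), compound 1 `COCCCCCCCCCCC/C=C1\CC(CO)(COC(=O)C(C)(C)C)OC1=O` gives 0.701 ug/mL. Compound 2 `CC(C)(C)C(=O)OCCCCCCCCCCCCCCC/C=C1\CC(CO)(COC(=O)C(C)(C)C)OC1=O` reads > 10 ug/mL, which is a limit and not a number. The series therefore shows (the limit of > 10 ug/mL in this assay, at which 1 of the 2 values shown sits).

Compound 3 `CC(=O)NCCCCCCCCCCCCCCC/C=C1\CC(CO)(COC(=O)C(C)(C)C)OC1=O` carries acetamido in place of ((tert-butyl)carbonyl)oxy on a saturated chain carbon, ten or more bonds along the chain from a double-bonded chain carbon.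

Among the compounds with values here, one measured step bears on this change: an at least 14-fold higher number from compound 1 to compound 2 (1.15 log units; beyond the scatter). It is large and beyond the scatter, and it replaces methoxy with 4-(((tert-butyl)carbonyl)oxy)butyl, also on a saturated chain carbon. Within the data shown here, no measured compound carries acetamido, so the direction is tentative. In this assay, a moderate move toward stronger inhibition of growth is expected, and a second limit remains possible. The expected change is an at least 2.5-fold lower number from compound 2 to compound 3 (0.39 log units; beyond the scatter). For compound 3, the estimated value is 4 ug/mL, with an expected range of 0.8 ug/mL to 20 ug/mL.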

Compound 3, concentration for 50% growth inhibition: 1.08 ug/mL
Estimate against measurement, compound 3: 3.7-fold (0.57 log units) above, and the stated range covers the measured number.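

At the far end of the chain, acetamido in place of ((tert-butyl)carbonyl)oxy brings the read-out in this assay back into the measurable range: an at least 9.2-fold lower number from compound 2 to compound 3 (0.96 log units; beyond the scatter). The size of this step is only a bound, and compound 2 is a limit rather than a number: the limit of > 10 ug/mL in this assay, at which 1 of the 3 values shown sits. Replacing methoxy with 4-acetamidobutyl gives no separable change, a 1.5-fold higher number from compound 1 to compound 3 (0.19 log units; within the scatter), so among these compounds added chain length on its own does not bring the loss seen with the ((tert-butyl)carbonyl)oxy end.

Still open, as far as these compounds go, is whether a free amine, a carboxylic acid or a plain hydroxyl at the chain end would match acetamido. Also open, from the compounds shown here alone, is whether acetamido would keep this activity on a shorter chain or a longer one.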